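This account rests on a few compounds, and the source may have more. Where it says the series, first, only, none or still open, it means among the compounds named here.

Compound 1 `N/C(=N\NC(=S)N1CCCC1)c1ccc(F)cn1` and compound 2 `N/C(=N\NC(=S)N1CCSCC1)c1ccccn1` share one core but differ in two places at once, so no single step can be read between them. In a functional assay on A-431 cells (Homo sapiens) for cytotoxicity, read by MTT assay, with a stated time of 72 h, tested at 30 uM (on this read-out higher numbers stand for more inhibition of growth at the one concentration tested and lower numbers for less inhibition of growth), compound 1 gives 83.3%. In this assay compound 2 gives 81.3%, and the two numbers lie within the usual scatter of each other, so the measurements do not tell compound 2 apart from compound 1. Compound 3 `N/C(=N\NC(=S)N1CCSCC1)c1ccc(F)cn1` has not yet been measured. It differs from compound 2 by fluoro in place of hydrogen on an aromatic carbon. Within the data shown here, no pair of measured compounds shows this change on its own, so its effect in this assay cannot be read from the data. Compound 1, which also carries fluoro at that place, gives 83.3%, a number close to that of compound 2, so no step beyond the scatter is expected here. Compound 3 is expected to give 82% in this assay, within 70% to 92%, which means an expected step of a number 0.7 percentage points higher from compound 2 to compound 3 (within the scatter).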

Compound 3, percent growth inhibition at one concentration: 84.6%
Compound 3: middle estimate off by 2.6 percentage points, on the low side; measured number inside the range.
By their numbers in this assay, from the lowest: compounds 2, 1 and 3 (each within the scatter of the next).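

Fluoro in place of hydrogen on an aromatic carbon, two atoms from the ring nitrogen, can now be read on its own: this assay shows a number 3.3 percentage points higher from compound 2 to compound 3 (within the scatter) for this change, so it cannot be told apart from no change at this position. Thiomorpholin-4-yl in place of pyrrolidin-1-yl on a thiocarbonyl carbon can also be read alone for the first time, with fluoro present in both compounds, and a number 1.3 percentage points higher from compound 1 to compound 3 (within the scatter) again leaves the two compounds indistinguishable. No measurement here offers an explanation for these results.

Going by these compounds, whether a methoxy group or a carboxylic acid at this ring position would move the number remains open, as does the effect of an open-chain dimethylamino group on the thiocarbonyl carbon. On these data alone, with readings from a single concentration, any differences that might appear at lower concentrations also remain unknown.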